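Swapping a hydroxy for a methyl on an inactive hydrazone

The source may report more compounds than this note shows. Statements on the series, on what has been measured and on what is new or still open speak of the compounds shown alone.

Compound 2 `CC1CC/C(=N\Nc2ccccc2O)c2ncc(C(=O)O)c(=O)n21` has only a limit in a functional assay on the whole organism for inhibition, with Rattus norvegicus as the target; on this read-out lower numbers stand for an effect already at smaller amounts and higher numbers for an effect only at larger amounts of compound: compound 2 gives > 100 umol/kg, which marks the highest dose tested and not a measured number. Its neighbour compound 1 `CC1CC/C(=N\Nc2ccc(F)cc2)c2ncc(C(=O)O)c(=O)n21` likewise reaches only a limit, giving > 1000 umol/kg. The step that the two limits leave unreadable from compound 1 to compound 2 therefore cannot be read. Compound 3 `Cc1ccccc1N/N=C1\CCC(C)n2c1ncc(C(=O)O)c2=O` differs from compound 2 by methyl in place of hydroxy on an aromatic carbon. Among the measured compounds shown here, no measured step bears on this change, so no step beyond the scatter is expected; the estimated step that the limit leaves unreadable from compound 2 to compound 3 is set near zero. Compound 3 is expected to give 400 umol/kg, within 100 umol/kg to 3000 umol/kg.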

Compound 3, dose for 50% inhibition: > 100 umol/kg
Compound 3 ended at the assay's limit; the forecaster's own chance of this, stated with the estimate: 70%; the middle value is on the limit's open side.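

In this assay, among the compounds shown here, the results for compound 1, compound 2 and compound 3 are all limits, so no step between them can be read. From the compounds shown here alone, the dose at which any of them inhibits remains open, as does whether methyl in place of hydroxy changes it.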